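Compound 1 to compound 4: hydrogen in place of acetyl

This account rests on a few compounds, and the source may have more. Where it says the series, first, only, none or still open, it means among the compounds named here.

In a functional assay on DU-145 cells (Homo sapiens) for cytotoxicity, read by MTT assay (a higher number here means a weaker inhibitor, a lower number a stronger inhibitor), three compounds have been measured. Compound 1 `CC(=O)OCCO[C@H](CC=C(C)C)C1=CC(=O)c2c(O)ccc(O)c2C1=O` gives 15500 nM. Compound 2 `CC(C)=CC[C@@H](OC(=O)C1CCCO1)C1=CC(=O)c2c(O)ccc(O)c2C1=O` gives 10500 nM. Compound 3 `CC(C)=CC[C@@H](OC(=O)c1ccco1)C1=CC(=O)c2c(O)ccc(O)c2C1=O` gives > 100000 nM, which is a limit of the assay rather than a number.

Among the two numbers, compound 1 stands nearest compound 2: a 1.5-fold lower number from compound 1 to compound 2 (0.17 log units; within the scatter). The remaining steps both run to the limit of compound 3: an at least 6.4-fold higher number from compound 1 to compound 3 (0.80 log units; beyond the scatter) and an at least 9.5-fold higher number from compound 2 to compound 3 (0.97 log units; beyond the scatter), see (the limit of > 100000 nM in this assay, at which 1 of the 3 values shown sits).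

Compound 4 `CC(C)=CC[C@@H](OCCO)C1=CC(=O)c2c(O)ccc(O)c2C1=O` differs from compound 1 by hydrogen in place of acetyl on an oxygen on a saturated carbon. Among the compounds with values here, no measured step strips the acyl group in this way; the one step that stays within the scatter, a 1.5-fold lower number from compound 1 to compound 2 (0.17 log units; within the scatter), exchanges one acyl group for another at the same oxygen, while the steps beyond the scatter both introduce the furan-2-yl group. Nothing here points to a change beyond the scatter for a hydroxy in place of an acetoxy. Compound 4 is therefore expected to give about 16000 nM, between 5000 nM and 50000 nM. The expected step is a 1.0-fold higher number from compound 1 to compound 4 (0.01 log units; within the scatter).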

Compound 4, half-maximal inhibitory concentration: 9900 nM
The estimate for compound 4 lay 1.6-fold (0.21 log units) above the measured number; measured number inside the range.
By their numbers in this assay, from the lowest: compounds 4, 2 and 1 (each within the scatter of the next). At a limit, above all of these: compound 3.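

In this assay, the acetyl on the 2-acetoxyethyl group turns out not to be needed: with hydrogen in its place on this oxygen, the reading stays within the scatter (a 1.6-fold lower number from compound 1 to compound 4 (0.19 log units; within the scatter)). The 2-hydroxyethyl group of compound 4 also reads like the (oxolan-2-yl)carbonyl group of compound 2 (a 1.1-fold lower number from compound 2 to compound 4 (0.03 log units; within the scatter)), so three different groups at this oxygen now sit together, and the earlier compounds had shown this for only two of them. Only compound 3 stands apart (an at least 10-fold lower number from compound 3 to compound 4 (1.00 log units; beyond the scatter)), and its value is a limit of the assay, not a number: (the limit of > 100000 nM in this assay, at which 1 of the 4 values shown sits).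

The compounds shown leave open whether an amine or a carboxylic acid at the end of this chain would stay at the same level. Going by these compounds, whether a longer chain would do so also remains open.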